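Thiazole for Ester: Expected Cell Toxicity of Compound 4

A few compounds are considered here, and "the series" means these few. Any claim that something is new, unique, unknown or untested is made for them only; others in the source may bear on it.

Compound 1 `CC(C)OC(=O)c1ccc(NCc2cncn2Cc2ccc(-c3ccccc3)cc2)cc1-c1ccccc1` was tested in a toxicity assay on NIH3T3 cells (Mus musculus) for cytotoxicity, read by resazurin assay; on this read-out lower numbers stand for an effect already at smaller amounts and higher numbers for an effect only at larger amounts of compound. There compound 1 stops at a limit of the assay, > 10000 nM, not a measured number. Compound 2 `COC(=O)c1ccc(NCc2cncn2Cc2ccc(F)cc2F)cc1-c1ccccc1` also reaches only a limit, > 1000 nM. Compound 3 `Cc1ccc(Cn2cncc2CNc2cccc(-c3ccccc3)c2)cc1` gives 10000 nM. Thus compound 1 stands among values that show harm only at large amounts, and no step between two measured compounds is available. Compound 4 `c1ccc(-c2ccc(Cn3cncc3CNc3ccc(-c4cncs4)c(-c4ccccc4)c3)cc2)cc1` differs from compound 1 in one place: 1,3-thiazol-5-yl in place of isopropoxycarbonyl on an aromatic carbon. For this change in this assay a step within the usual scatter is expected, in no clear direction. Compound 4 is therefore estimated at 15000 nM, with a range from 5000 nM to 50000 nM. The expected step is a step that the limit leaves unreadable from compound 1 to compound 4.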

Compound 4, half-maximal effective concentration: > 1000 nM
Compound 4 was reported as a limit (the forecaster's own chance of this, stated with the estimate: 65%); the middle value does not contradict the limit.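

For the compounds shown here, compound 1 and compound 4 both stop at limits of this assay, not at measured numbers, and no step between them can be read. The compounds shown leave open whether 1,3-thiazol-5-yl in place of isopropoxycarbonyl changes cell toxicity at all.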